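This account rests on a few compounds, and the source may have more. Where it says the series, first, only, none or still open, it means among the compounds named here.

Measured compounds, in a functional assay on U2OS cells for positive allosteric modulation of metabotropic glutamate receptor 5 (Homo sapiens), read by calcium flux, in the presence of a further agent that is not named here; on this read-out lower numbers stand for an effect already at smaller amounts and higher numbers for an effect only at larger amounts of compound:
compound 1, `Fc1ccc(-c2noc(C3CCc4c(nnn4-c4ccc(F)cc4)C3)n2)cc1`, 15.9 nM
compound 2, `Fc1ccc(-c2noc(C3CCc4c(nnn4-c4ccc(F)nc4)C3)n2)cc1`, a limit of this assay, > 25100 nM
compound 3, `Fc1ccc(-c2noc(C3CCc4c(nnn4C4CCOC4)C3)n2)cc1`, 398 nM

All three share one core and differ only in the group on an aromatic nitrogen. For compound 2 the reported value is a limit and not a number (the limit of > 25100 nM in this assay, at which 1 of the 3 values shown sits). Of the two numbers, compound 3 is the higher, with compound 1 the nearest: a 25-fold higher number from compound 1 to compound 3 (1.40 log units; beyond the scatter). The remaining steps are an at least 1500-fold higher number from compound 1 to compound 2 (3.19 log units; beyond the scatter) and an at least 63-fold lower number from compound 2 to compound 3 (1.79 log units; beyond the scatter).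

Compound 4, `CC(C)n1nnc2c1CCC(c1nc(-c3ccc(F)cc3)no1)C2`, is not yet measured. Against compound 3 the change is isopropyl in place of oxolan-3-yl on an aromatic nitrogen. Among the compounds with values here, no measured step exchanges one non-aromatic group for another; the only step that bears on it is a 25-fold higher number from compound 1 to compound 3 (1.40 log units; beyond the scatter), where the 4-fluorophenyl gave way to oxolan-3-yl, and compound 4 keeps a non-aromatic group in that place. The expected step is therefore a 1.3-fold higher number from compound 3 to compound 4 (0.10 log units; within the scatter), not beyond the scatter. For compound 4 in this assay the estimate is 500 nM, within 160 nM to 1600 nM.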

Compound 4, half-maximal effective concentration: 398 nM
Compound 4: middle estimate off by 1.3-fold (0.10 log units), on the high side; the range from low to high includes it.
By their numbers in this assay, from the lowest: compound 1; then compounds 3 and 4 (each within the scatter of the next). At a limit, above all of these: compound 2.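

In this assay the exchange on the aromatic nitrogen gives no change at the digits printed from compound 3 to compound 4 (within the scatter) and so shows that, for this pair, losing the ring and the hydrogen-bond acceptor of oxolan-3-yl leaves no mark on this read-out. The distance from 4-fluorophenyl is also not peculiar to oxolan-3-yl, for isopropyl gives a 25-fold higher number from compound 1 to compound 4 (1.40 log units; beyond the scatter) and two non-aromatic groups now sit level, with 4-fluorophenyl at the lower number. The remaining step of an at least 63-fold lower number from compound 2 to compound 4 (1.79 log units; beyond the scatter) rests on a limit and not a number: the limit of > 25100 nM in this assay, at which 1 of the 4 values shown sits.

What a longer chain such as n-butyl, a small ring such as cyclopropyl or an amine such as piperidin-4-yl would give on this nitrogen stays open, as isopropyl and oxolan-3-yl are the only non-aromatic groups shown. Also open, on these data alone, is how far the sharp gap between the two aromatic groups extends, which a plain phenyl or an unsubstituted pyridin-3-yl on the same core would help to settle.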